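Fluorine on the Triazole Phenyl: What to Expect

The source may hold more compounds than are shown below. What is called first, only, known or untested is meant among the compounds shown, and "the series" means these compounds.

Measured so far:
compound 1: `CC(C)n1ncc2c(C(=O)Nc3cccnc3)cccc21`, > 40000 nM
compound 2: `CC(C)n1ncc2c(C(=O)NCc3cn(-c4ccccc4)nn3)cccc21`, > 40000 nM

In a functional assay on MCF7 cells (Homo sapiens) for inhibition, read by MTT assay, with a stated time of 72 h (on this read-out lower numbers stand for stronger inhibition and higher numbers for weaker inhibition), compound 1 gives no number but only a limit, > 40000 nM. In this assay compound 2 also gives only a limit, > 40000 nM. Compound 2 therefore stands nowhere distinguishable from the single other measured compound; both shown values sit at the limit of > 40000 nM in this assay, at which 2 of the 2 values shown sit. Within the data shown here, no step between two measured compounds is available, so nothing in this assay tells how any change to the core of compound 2 shifts the read-out.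

Compound 3, `CC(C)n1ncc2c(C(=O)NCc3cn(-c4ccc(F)cc4)nn3)cccc21`, is not yet measured. It differs from compound 2 by fluoro in place of hydrogen on an aromatic carbon. A change of this size, with no measured comparison to lean on, is expected to move the value by no more than the usual scatter, in no particular direction. The step from compound 2 to compound 3 is accordingly estimated as a step that the limit leaves unreadable from compound 2 to compound 3. For compound 3 the expected value in this assay is 60000 nM, with a range from 20000 nM to 200000 nM, and most probably again only a limit would be reported.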

Compound 3, half-maximal inhibitory concentration: > 40000 nM
Compound 3: a limit, no number (the forecaster's own chance of this, stated with the estimate: 80%); the middle value is on the limit's open side.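

In this assay compound 3 gives only a limit, > 40000 nM. Compound 2 likewise gives only a limit, so no step can be read between these two compounds, and the change from phenyl to 4-fluorophenyl has no readable size. The compounds shown leave open which change would yield a number rather than a limit: the limit of > 40000 nM in this assay, at which 3 of the 3 values shown sit.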